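This account rests on a few compounds, and the source may have more. Where it says the series, first, only, none or still open, it means among the compounds named here.

Measured compounds:
Compound 1 `O=C(CCCCC1CCSS1)Nc1cccc(C(F)(F)F)c1` gives 5%
Compound 2 `O=C(CCCCC1CCSS1)Nc1cccc2ccccc12` gives 0.34%
Compound 3 `O=C(CCCCC(S)CCS)Nc1cccc(C(F)(F)F)c1` gives 10.8%

All three numbers come from a functional assay on HO8910 cells (Homo sapiens) for inhibition, read by MTT assay, with a stated time of 24 h, tested at 0.1 ug/mL; a higher number here means more inhibition of growth at the concentration tested, a lower number less inhibition of growth. Compound 1 and compound 3 share a core and differ in a single place: a group of 5 heavy atoms (3 carbon, 2 sulfur; no ring) in place of a group of 5 heavy atoms (3 carbon, 2 sulfur; one five-membered non-aromatic ring with 2 hetero atoms), on a saturated chain carbon, four bonds along the chain from a carbonyl carbon. The step that this change made is a number 5.8 percentage points higher from compound 1 to compound 3 (within the scatter), so within this pair the opening of the ring into the open-chain form left the growth inhibition essentially where it was.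

Compound 2 carries a different aromatic part on the amide nitrogen from compound 1; the difference between the two cores is not broken down here. Its value is the lowest of the three, but the gap to compound 1 is within the scatter, while the number for compound 3 stands higher than that of compound 2 by an amount beyond the scatter.

Compound 4 `O=C(CCCCC(S)CCS)Nc1cccc2ccccc12` has not yet been tested. It stands to compound 2 as compound 3 stands to compound 1: a group of 5 heavy atoms (3 carbon, 2 sulfur; no ring) in place of a group of 5 heavy atoms (3 carbon, 2 sulfur; one five-membered non-aromatic ring with 2 hetero atoms), on a saturated chain carbon, four bonds along the chain from a carbonyl carbon. The place of the change is the same in words in both pairs, so this is the same change on a different core. Because the earlier step was a number 5.8 percentage points higher from compound 1 to compound 3 (within the scatter), the step from compound 2 to compound 4 in this assay is expected to be of similar size, a number 5.7 percentage points higher from compound 2 to compound 4 (within the scatter). Compound 4 is therefore estimated at 6%, with a likely range from -2% to 16%; this rests on one measured pair only.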

Compound 4, percent growth inhibition at one concentration: 0.76%
Compound 4: the middle estimate sits 5.2 percentage points above what was measured; low and high end bracket the measured number.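

In this assay, putting the open-chain 1,3-disulfanylpropyl group in place of the five-membered ring with two sulfur atoms gives a number 0.4 percentage points higher from compound 2 to compound 4 (within the scatter), so on this second core too the change leaves growth inhibition essentially where it was. Set beside the earlier pair, the change behaves alike on the two cores: the same change on two cores in this assay, a number 5.8 percentage points higher (within the scatter) from compound 1 to compound 3 and a number 0.4 percentage points higher (within the scatter) from compound 2 to compound 4, 5.4 percentage points apart, within the scatter of two such steps This agreement rests on only two pairs, read in one cell line at one concentration, and neither step stands beyond the scatter, so it does not show that opening the ring raises growth inhibition, nor that the same result would hold on a third core.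

The compounds shown leave open what other groups would do at this place on the saturated chain, such as an amine, a carboxylic acid, or a longer chain carrying the same two sulfur atoms. They also leave open how the ring and open-chain forms compare at higher concentrations, where the readings might stand further apart, and with other aromatic groups on the amide nitrogen.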